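Series notes: replacing the urea terminus on compound 1

This account rests on a few compounds, and the source may have more. Where it says the series, first, only, none or still open, it means among the compounds named here.

Measured compounds:
compound 1, `NC(=O)NC/C=C\CN(C[C@H]1Cc2ccccc2CN1)[C@H]1CCCc2cccnc21`: 210 nM
compound 2, `N[C@H]1CC[C@H](N(C[C@H]2Cc3ccccc3CN2)[C@H]2CCCc3cccnc32)CC1`: 34 nM

Going by the values given here, in a functional assay on CCRF-CEM cells for antagonist activity at C-X-C chemokine receptor type 4 (Homo sapiens), read by calcium flux, with stated times of 25 min and 90 s (a lower number here means a stronger inhibitor, a higher number a weaker inhibitor), compound 1 gives 210 nM and stands as the higher of the two numbers recorded; compound 2 gives 34 nM, with a 6.2-fold lower number from compound 1 to compound 2 (0.79 log units; beyond the scatter) as the only measured step in the set.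

The unmeasured compound 3, `FC1(F)CCC(NC/C=C\CN(C[C@H]2Cc3ccccc3CN2)[C@H]2CCCc3cccnc32)CC1`, differs from compound 1 by 4,4-difluorocyclohexyl in place of carbamoyl on an amine nitrogen; cut one bond further out this reads ureido to (4,4-difluorocyclohexyl)amino. The step from compound 1 to compound 2 bears on this only loosely: there the whole chain on the amine nitrogen was exchanged for a ring-bearing group, whereas compound 3 keeps the chain and swaps only its terminus. That step was modest and went to a lower number. By analogy, the expected outcome for compound 3 in this assay is a lower number than compound 1, by a smaller step, estimated at about a 2.3-fold lower number from compound 1 to compound 3 (0.37 log units; beyond the scatter). Compound 3 is therefore estimated at 90 nM, with a range from 30 nM to 300 nM.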

Compound 3, half-maximal inhibitory concentration: 98 nM
Compound 3: the middle estimate sits 1.1-fold (0.04 log units) below what was measured, within the range that was stated.
By their numbers in this assay, from the lowest: compound 2; then compound 3; then compound 1.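

In this assay the exchange of carbamoyl for 4,4-difluorocyclohexyl on the amine nitrogen gives a 2.1-fold lower number from compound 1 to compound 3 (0.33 log units; beyond the scatter) with the chain left in place. A change at the terminus alone therefore moves the number, which the earlier pair could not show, since the whole chain on the amine nitrogen differs between compound 1 and compound 2. The entering group has 0 hydrogen-bond donors and 0 hydrogen-bond acceptors against 1 of each in carbamoyl, and 8 heavy atoms against 3, so for this pair neither the donor and acceptor of carbamoyl nor a terminus of that small size is needed for the number to stay as low as it does; nothing measured here accounts for the step.

The compounds shown leave open whether the step belongs to the six-membered ring or to the two fluorine atoms, which a plain cyclohexyl on the same amine nitrogen would separate. They also leave open how a small group such as methyl, or a terminus carrying a carboxylic acid, would read at this position.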